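Selenium to sulfur on the amidine carbon, furan series

The source may report more compounds than this note shows. Statements on the series, on what has been measured and on what is new or still open speak of the compounds shown alone.

Compound 1 `C[Se]/C(=N\C(=O)c1cc2ccccc2s1)NC(=O)c1cc2ccccc2s1`: in a functional assay on HT-29 cells (Homo sapiens) for cytotoxicity, read by MTT assay, with a stated time of 72 h (a higher number here means that more compound is tolerated, a lower number that less compound is tolerated), compound 1 shows only a limit of the assay, > 100000 nM.
Compound 2 `C[Se]/C(=N\C(=O)c1ccco1)NC(=O)c1ccco1`: in this assay compound 2 likewise shows only a limit, > 100000 nM.
Compound 3 `CS/C(=N\C(=O)c1cc2ccccc2s1)NC(=O)c1cc2ccccc2s1`: in this assay compound 3 gives 88200 nM.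

Compound 1 and compound 3 share a core and differ by a group of 2 heavy atoms (1 carbon, 1 sulfur; no ring) in place of a group of 2 heavy atoms (1 carbon, 1 selenium; no ring), on a carbon with a double bond to nitrogen. The step of an at least 1.1-fold lower number from compound 1 to compound 3 (0.05 log units; that floor lies within the scatter) is small, and its true size is not resolved because the limit of > 100000 nM in this assay, at which 2 of the 3 values shown sit, leaves compound 1 without a number. Compound 2 carries the same selenium group on a different core; the difference between the two cores is not broken down here.

The compound not yet measured is compound 4 `CS/C(=N\C(=O)c1ccco1)NC(=O)c1ccco1`. It is obtained from compound 2 by a group of 2 heavy atoms (1 carbon, 1 sulfur; no ring) in place of a group of 2 heavy atoms (1 carbon, 1 selenium; no ring), on a carbon with a double bond to nitrogen, and the surroundings of the change, as described for both pairs, are the same in every word, so this is the same change as from compound 1 to compound 3.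

On that basis compound 4 is expected to behave much like its selenium partner, and the step from compound 2 to compound 4 is estimated as a step that the limit leaves unreadable from compound 2 to compound 4 in this assay, resting on the small step of an at least 1.1-fold lower number from compound 1 to compound 3 (0.05 log units; that floor lies within the scatter) and on the limit of compound 2, > 100000 nM. Compound 4 is therefore estimated at 130000 nM, within 50000 nM to 400000 nM, and it may well again return only a limit.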

Compound 4, concentration lethal to 50% of the cells: > 100000 nM
Compound 4: no number, only a limit; the forecaster's own chance of this, stated with the estimate: 65%; the middle value lies beyond the limit too.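

In this assay compound 2 and compound 4 both return only a limit, so no step between them can be read and the exchange of the selenium group for methylsulfanyl has no size in this pair: the limit of > 100000 nM in this assay, at which 3 of the 4 values shown sit.

The compounds shown leave open what numbers compound 1, compound 2 and compound 4 would take, and so whether this exchange alters the result in this assay on either core.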